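Solubility of a Pyrrole Series: Predicting the Ester Analogue

The compounds below may be only part of what the source reports. "The series", "measured", "known", "first", "only" and "open" are said of these compounds alone.

Measured compounds:
- compound 1, `CCC(=O)c1cc(-c2ccc(OC)cc2)n(-c2ccc(S(N)(=O)=O)cc2)c1C`: 12800 nM
- compound 2, `CCOC(=O)c1cc(-c2ccc(OC)cc2)n(-c2ccc(S(N)(=O)=O)cc2)c1C`: 16100 nM
- compound 3, `CCC(=O)c1cc(-c2ccc(F)cc2)n(-c2ccc(S(N)(=O)=O)cc2)c1`: 63000 nM

All three were tested in a physicochemical assay for solubility, read by HPLC, in phosphate buffer, measured as kinetic solubility, at pH 7.4; on this read-out lower numbers stand for lower solubility and higher numbers for higher solubility. Compound 1 and compound 2 share one core and differ in a single place: ethoxy in place of ethyl on a carbonyl carbon. That change gave a 1.3-fold higher number from compound 1 to compound 2 (0.10 log units; within the scatter), so on this read-out the two values cannot be told apart. Compound 3 sits on a different core, and its difference from compound 1 is not broken down here; compound 3 gives 63000 nM, the highest of the three numbers.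

Compound 4, `CCOC(=O)c1cc(-c2ccc(F)cc2)n(-c2ccc(S(N)(=O)=O)cc2)c1`, is not yet measured. It stands to compound 3 as compound 2 stands to compound 1, and the change is the same: ethoxy in place of ethyl on a carbonyl carbon. For the measured compounds named here, the only guide to its size is the step seen between compound 1 and compound 2, which stayed within the scatter. The expected step is therefore small, a 1.3-fold higher number from compound 3 to compound 4 (0.10 log units; within the scatter), and it rests on that single earlier pair. Compound 4 is estimated at 80000 nM in this assay, with a likely range from 40000 nM to 160000 nM.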

Compound 4, solubility: 36400 nM
Beside the measured number, compound 4's estimate is 2.2-fold (0.34 log units) above it; measured number outside the range, below it.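

In this assay, putting ethoxy in place of ethyl on the carbonyl carbon gave a 1.7-fold lower number from compound 3 to compound 4 (0.24 log units; within the scatter), while the same change on the core of compound 1 gave a 1.3-fold higher number from compound 1 to compound 2 (0.10 log units; within the scatter). Both steps lie within the usual scatter, so each pair of values cannot be told apart, and the opposite directions of the two steps do not amount to a real reversal; on these two cores, the change carried over as a step too small to resolve. Two pairs do not show that this would hold on any further core, and no measurement here explains the values.

The compounds shown leave open what happens when the carbonyl carbon carries a longer chain, such as butoxy, or an amine in place of ethoxy. Going by these compounds, a carboxylic acid at the same place is equally open, so the reach of this result beyond the ethyl and ethoxy pairs remains unknown.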